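The compounds below may be only part of what the source reports. "The series", "measured", "known", "first", "only" and "open" are said of these compounds alone.

Measured so far in an in vitro functional assay on HEK293-A cells for antagonist activity at metabotropic glutamate receptor 5 (Rattus norvegicus), read by calcium flux; a higher number here means a weaker inhibitor, a lower number a stronger inhibitor:

Compound 1, `O=C(Nc1cccc(NC(=O)c2cccc(Cl)c2)c1)c1ccc(Cl)cc1` — in this assay compound 1 reaches only a limit, > 30000 nM.
Compound 2, `O=C(Nc1cccc(NC(=O)c2ccc(Cl)c(Cl)c2)c1)c1cccc(Cl)c1` — in this assay compound 2 likewise gives only a limit, > 30000 nM.
Compound 3, `O=C(Nc1cccc(NC(=O)C2CCCCC2)c1)c1cccc(Cl)c1` — in this assay compound 3 also stops at a limit, > 30000 nM.

Compound 3 therefore stands nowhere in particular on these numbers: it sits at the same limit as the other two, and nothing ranks the three against each other (the limit of > 30000 nM in this assay, at which 3 of the 3 values shown sit). The changes among them leave no readable step: a step that the two limits leave unreadable from compound 1 to compound 2; a step that the two limits leave unreadable from compound 1 to compound 3; a step that the two limits leave unreadable from compound 2 to compound 3. In particular the exchange of an aromatic ring for a saturated ring on the carbonyl carbon, from compound 1 or compound 2 to compound 3, produced no number at all.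

Compound 4, `O=C(Nc1cccc(NC(=O)C2CCC2)c1)c1cccc(Cl)c1`, is compound 3 with a smaller saturated ring on that same carbon: cyclobutyl in place of cyclohexyl on a carbonyl carbon. The two steps that bear on it, those ending at compound 3, are both unreadable, so no direction and no size can be drawn from them. The expected step is accordingly a number no higher from compound 3 to compound 4 (the limit leaves the size open), a move from one limit to what is most likely another limit. Compound 4 is expected to give about 30000 nM in this assay, within 10000 nM to 100000 nM, most probably reported only as a limit again.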

Compound 4, half-maximal inhibitory concentration: 5270 nM
For compound 4 the middle estimate is 5.7-fold (0.76 log units) above the measured one; the whole stated range lies above it.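

In this assay the position on the carbonyl carbon gives its first readable response: cyclobutyl in place of cyclohexyl produces an at least 5.6-fold lower number from compound 3 to compound 4 (0.75 log units; beyond the scatter), whereas the steps among compound 1, compound 2 and compound 3 cannot be read. Cyclobutyl also separates from both aromatic rings held at this position, with an at least 5.6-fold lower number from compound 2 to compound 4 (0.75 log units; beyond the scatter) for the exchange of 3,4-dichlorophenyl and an at least 5.6-fold lower number from compound 1 to compound 4 (0.75 log units; beyond the scatter) for the exchange of 4-chlorophenyl, although compound 1 and compound 2 also differ from each other elsewhere. The choice of group at this position is therefore not indifferent, and among the four compounds only compound 4 gives a number rather than a limit: the limit of > 30000 nM in this assay, at which 3 of the 4 values shown sit.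

On these data alone, each of the three steps is a bound set by a limit, so its full size stays open. As far as these compounds go, whether the response follows ring size also remains open, and a cyclopropyl or cyclopentyl ring, an open chain such as isopropyl, or an amine such as azetidine on the same carbonyl carbon would test how narrow the cyclobutyl result is.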